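A few compounds are considered here, and "the series" means these few. Any claim that something is new, unique, unknown or untested is made for them only; others in the source may bear on it.

- compound 1 `CN1C[C@H](C(=O)Nc2ccc(Cl)cc2F)[C@@H](c2ccc(/C=C/C(=O)Nc3ccccc3N)cc2)C1` with 43 mL/min/kg
- compound 2 `Cc1ccc(NC(=O)[C@H]2CN(C)C[C@@H]2c2ccc(/C=C/C(=O)Nc3ccccc3N)cc2)cn1` with 57 mL/min/kg

Among the compounds with values here, in an in vitro ADME assay on microsomes from liver (Mus musculus) for pharmacokinetics, read by LC-MS, with a stated time of 10 min, tested at 1 uM (on this read-out lower numbers stand for slow clearance and higher numbers for fast clearance), compound 2 gives 57 mL/min/kg and stands within the scatter of compound 1, the only other measured compound. Compound 3 `CN1C[C@H](C(=O)Nc2ccccn2)[C@@H](c2ccc(/C=C/C(=O)Nc3ccccc3N)cc2)C1` has pyridin-2-yl in place of 6-methylpyridin-3-yl on an amide-type nitrogen. Within the data shown here, the one measured step at that nitrogen (a 1.3-fold higher number from compound 1 to compound 2 (0.12 log units; within the scatter)) lay within the scatter, so no change beyond the scatter is expected, though a single step is thin evidence. The estimated step (a 1.1-fold lower number from compound 2 to compound 3 (0.06 log units; within the scatter)) is accordingly small. Compound 3 is expected at 50 mL/min/kg with an estimated range from 25 mL/min/kg to 100 mL/min/kg in this assay.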

Compound 3, clearance: 40 mL/min/kg
Compound 3: the middle estimate sits 1.3-fold (0.10 log units) above what was measured, and the stated range covers the measured number.
By their numbers in this assay, from the lowest: compounds 3, 1 and 2 (each within the scatter of the next).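

In this assay, pyridin-2-yl on the amide-type nitrogen gives a 1.4-fold lower number from compound 2 to compound 3 (0.15 log units; within the scatter) and a 1.1-fold lower number from compound 1 to compound 3 (0.03 log units; within the scatter), so all three groups seen at this position now lie within the scatter of one another. This position has so far tolerated a third aromatic group, one without a methyl, chlorine or fluorine substituent, with no clear shift in clearance. Nothing available here explains this. From the compounds shown here alone, whether cyclohexyl or a longer chain ending in an amine at this nitrogen would move clearance beyond the scatter stays open. So does the effect of any change elsewhere on the shared core.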